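From 4-methylpiperazin-1-yl to diethylamino on the chain

A few compounds are considered here, and "the series" means these few. Any claim that something is new, unique, unknown or untested is made for them only; others in the source may bear on it.

Measured in a functional assay on MGC-803 cells (Homo sapiens) for cytotoxicity, read by MTT assay, with a stated time of 38 h; a higher number here means a weaker inhibitor, a lower number a stronger inhibitor:
Compound 1 `COc1cc(OC)c2c(=O)c(OCCCCN3CCCCC3)c(-c3cc(OC)c(OC)c(OC)c3)oc2c1`: 26800 nM
Compound 2 `COc1cc(OC)c2c(=O)c(OCCCN3CCCC3)c(-c3cc(OC)c(OC)c(OC)c3)oc2c1`: 32100 nM
Compound 3 `COc1cc(OC)c2c(=O)c(OCCCCN3CCN(C)CC3)c(-c3cc(OC)c(OC)c(OC)c3)oc2c1`: 12200 nM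

Compound 3 gives the lowest number of the three. Compound 4 `CCN(CC)CCCOc1c(-c2cc(OC)c(OC)c(OC)c2)oc2cc(OC)cc(OC)c2c1=O` differs from it by diethylamino in place of (4-methylpiperazin-1-yl)methyl on a saturated chain carbon, three bonds along the chain from an oxygen on an aromatic ring. Of the measured compounds, only compound 3 carries the 4-methylpiperazin-1-yl group. Two modest steps lead to it: a 2.2-fold lower number from compound 1 to compound 3 (0.34 log units; beyond the scatter) and a 2.6-fold lower number from compound 2 to compound 3 (0.42 log units; beyond the scatter). By contrast, a 1.2-fold higher number from compound 1 to compound 2 (0.08 log units; within the scatter) between the two compounds without that group. Compound 4 also lacks the group, so a modest rise is expected in this assay, reversing those two steps. The expected change is a 2.1-fold higher number from compound 3 to compound 4 (0.33 log units; beyond the scatter). For compound 4 the estimated value is 26000 nM, within an expected range of 11000 nM to 55000 nM.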

Compound 4, half-maximal inhibitory concentration: 40200 nM
Compound 4: the middle estimate sits 1.5-fold (0.19 log units) below what was measured; the range from low to high includes it.
By their numbers in this assay, from the lowest: compound 3; then compounds 1, 2 and 4 (each within the scatter of the next).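

In this assay, diethylamino, which has no ring, does not match the 4-methylpiperazin-1-yl group, with a 3.3-fold higher number from compound 3 to compound 4 (0.52 log units; beyond the scatter). It is not separated from the other two amines, with a 1.3-fold higher number from compound 2 to compound 4 (0.10 log units; within the scatter) and a 1.5-fold higher number from compound 1 to compound 4 (0.18 log units; within the scatter). Compound 3 thus stands apart from all three, and a ring alone does not account for this, as compounds 1 and 2 also carry one.

As far as these compounds go, whether a 3-(4-methylpiperazin-1-yl)propyl or a 4-(morpholin-4-yl)butyl group would keep the lower number remains open. Nothing available explains these differences.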